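Chloro on the benzyl group of compound 2

This account rests on a few compounds, and the source may have more. Where it says the series, first, only, none or still open, it means among the compounds named here.

In a functional assay on NCI-H460 cells (Homo sapiens) for cytotoxicity, read by MTT assay, with a stated time of 72 h (a lower number here means a stronger inhibitor, a higher number a weaker inhibitor), compound 1 `CCN(CC)Cc1ccc2nc(NC(=O)N/N=C/c3cn(Cc4ccc(Cl)cc4Cl)c4ccccc34)sc2c1` gives 1080 nM and compound 2 `CCN(CC)Cc1ccc2nc(NC(=O)N/N=C/c3cn(Cc4ccccc4)c4ccccc34)sc2c1` gives 450 nM as the lower of the two numbers. Compound 3 `CCN(CC)Cc1ccc2nc(NC(=O)N/N=C/c3cn(Cc4ccccc4Cl)c4ccccc34)sc2c1` is still unmeasured. It differs from compound 2 by chloro in place of hydrogen on an aromatic carbon and so carries 2-chlorobenzyl in place of benzyl. Among the measured compounds shown here, the only measured step that bears on this is a 2.4-fold lower number from compound 1 to compound 2 (0.38 log units; beyond the scatter) with phenyl in place of 2,4-dichlorophenyl, a modest change. The 2-chlorophenyl of compound 3 lies structurally between the groups of compound 1 and compound 2, so a higher number than for compound 2 is expected in this assay by a smaller step, possibly within the scatter. One step cannot show how much each chloro contributes. Compound 3 is expected at 650 nM with an estimated range from 300 nM to 1400 nM as the likely span. This estimate means a 1.4-fold higher number from compound 2 to compound 3 (0.16 log units; within the scatter) as the expected step.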

Compound 3, half-maximal inhibitory concentration: 980 nM
The estimate for compound 3 lay 1.5-fold (0.18 log units) below the measured number, and the stated range covers the measured number.
By their numbers in this assay, from the lowest: compound 2; then compounds 3 and 1 (each within the scatter of the next).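

In this assay one chloro on the benzyl group is enough for a 2.2-fold higher number from compound 2 to compound 3 (0.34 log units; beyond the scatter) and so for a change that can be read on its own. Hydrogen in place of the second chloro of the 2,4-dichlorophenyl group gives a 1.1-fold lower number from compound 1 to compound 3 (0.04 log units; within the scatter) and so no readable change at that aromatic carbon. The difference between benzyl and 2,4-dichlorobenzyl, which a single step could not divide, therefore goes with the chloro of 2-chlorobenzyl in these three compounds.

On these data alone, whether 4-chlorobenzyl, with its lone chloro on the other carbon, would behave like 2-chlorobenzyl remains open. So does whether fluoro, methyl or methoxy on the same aromatic carbon would follow chloro. No measurement shown here accounts for the result.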